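This account rests on a few compounds, and the source may have more. Where it says the series, first, only, none or still open, it means among the compounds named here.

Among the compounds with values here, compound 2 `COc1ccc(C(=O)/C=C/c2cc(-c3cc(OC)c(OC)c(OC)c3)n[nH]2)cc1OC` gives 99% in a functional assay on HCT-116 cells (Homo sapiens) for cytotoxicity, read by sulforhodamine B assay, with a stated time of 48 h, tested at 0.01 uM; a lower number here means a stronger effect, a higher number a weaker effect of the compound at the concentration tested; this is the higher of the two numbers so far, with compound 1 `COc1cc(-c2cc(/C=C/C(=O)c3ccc(N)cc3)[nH]n2)cc(OC)c1OC` at 95%, and the step of a number 4 percentage points higher from compound 1 to compound 2 (within the scatter) lies within the scatter. Compound 3 `COc1cc(-c2cc(/C=C/C(=O)c3ccc(F)c(F)c3)[nH]n2)cc(OC)c1OC` is the next member: 3,4-difluorophenyl in place of 3,4-dimethoxyphenyl on a carbonyl carbon. Within the data shown here, the one measured step that bears on it, from compound 1 to compound 2, also exchanged the aryl on the carbonyl carbon and moved the read-out by a number 4 percentage points higher from compound 1 to compound 2 (within the scatter) only. On that basis no step beyond the scatter is expected, so a number 3 percentage points lower from compound 2 to compound 3 (within the scatter) is the estimated step. Compound 3 is therefore expected to give about 96%, within 86% to 104%.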

Compound 3, a percentage reported as activity, at one concentration (the size of the read-out at that concentration, not a potency): 101%
Estimate against measurement, compound 3: 5 percentage points below, within the range that was stated.
By their numbers in this assay, from the lowest: compounds 1, 2 and 3 (each within the scatter of the next).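

In this assay, the aryl on the carbonyl carbon now spans three groups without a step beyond the scatter: a number 2 percentage points higher from compound 2 to compound 3 (within the scatter) and a number 6 percentage points higher from compound 1 to compound 3 (within the scatter). 3,4-Difluorophenyl carries no hydrogen-bond donors or acceptors, so at this concentration the read-out does not separate it from 3,4-dimethoxyphenyl or 4-aminophenyl. Nothing available accounts for these numbers.

Open, going by these compounds, is whether any group at this position can move the read-out beyond the scatter, for example a carboxylic acid or a longer chain in place of the aryl. Also open, on these data alone, is whether the three compounds would separate at a higher concentration.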